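The source may report more compounds than this note shows. Statements on the series, on what has been measured and on what is new or still open speak of the compounds shown alone.

Measured in a functional assay on HepG2 cells (Homo sapiens) for inhibition, read by scintillation counting, with a stated time of 2 h; on this read-out lower numbers stand for stronger inhibition and higher numbers for weaker inhibition:

compound 1 `CCNC(=O)Nc1sc2ccccc2c1C(=O)N1CCN(C2CCN(C(=O)C(C)C)CC2)CC1`: "not determined" (no result reported)
compound 2 `CCNC(=O)Nc1sc2ccccc2c1C(=O)N1CCN(C2CCN(C(=O)OC3CCCCC3)CC2)CC1`: 635 nM
compound 3 `CCNC(=O)Nc1sc2cc(C)ccc2c1C(=O)N1CCN(C2CCN(C(=O)C(C)C)CC2)CC1`: 628 nM

Only two of these compounds have a number to compare. Compound 3 gives 628 nM, and this lies within the usual scatter of the value for compound 2, so the two cannot be told apart. Compound 1 offers no number for comparison.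

The next compound to be tested is compound 4 `CCNC(=O)Nc1sc2cc(C)ccc2c1C(=O)N1CCN(C2CCN(C(=O)C(C)(C)CF)CC2)CC1`. Its structure follows from compound 3 by placing fluoromethyl in place of hydrogen on a saturated chain carbon bound to a carbonyl carbon and two saturated chain carbons. In other words, isopropyl becomes 1-(fluoromethyl)-1-methylethyl.

Going by the values given here, no measured pair differs in one place only, so the data give little guidance. Compound 3 and compound 2 differ in more than one place, yet compound 2 at 635 nM lies within the scatter of compound 3. On this slim basis, no step beyond the scatter is expected in this assay, with only a slight lean toward a lower number. The expected step is a 1.4-fold lower number from compound 3 to compound 4 (0.14 log units; within the scatter). For compound 4 the estimated value is 450 nM, with an expected range of 150 nM to 1300 nM.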

Compound 4, half-maximal inhibitory concentration: 73 nM
The estimate for compound 4 lay 6.2-fold (0.79 log units) above the measured number; the measured number lies below the stated range.
By their numbers in this assay, from the lowest: compound 4; then compounds 3 and 2 (each within the scatter of the next).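

The saturated chain carbon bound to a carbonyl carbon and two saturated chain carbons turns out to be a sensitive place in this assay, as changing isopropyl to 1-(fluoromethyl)-1-methylethyl gives an 8.6-fold lower number from compound 3 to compound 4 (0.93 log units; beyond the scatter) in a single change. Going by these compounds alone, this is the first pair here that differs in one place only, and it shows that fluoromethyl, which adds no ring and no net charge, is enough to move the number beyond the scatter. Nothing measured here accounts for this drop.

From the compounds shown here alone, it remains open whether the fluorine matters or the added carbon alone would give a similar step, which a methyl, a hydroxymethyl or a longer chain on the same carbon could test. Going by these compounds, it is also open whether the step would hold on the core of compound 1.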